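A few compounds are considered here, and "the series" means these few. Any claim that something is new, unique, unknown or untested is made for them only; others in the source may bear on it.

Compound 3 `CCc1cccc2c(OC)c(-c3occ(C)c3COC)ccc12` gives the highest number of the three measured compounds: in a functional assay on KBVIN cells (Homo sapiens) for cytotoxicity, read by MTT assay, with a stated time of 72 h (on this read-out higher numbers stand for an effect only at larger amounts of compound and lower numbers for an effect already at smaller amounts), compound 3 gives 8.8 ug/mL. Its nearest neighbour is compound 2 `CCc1cccc2c(OC)c(-c3occ(C)c3C(=S)OC)ccc12`, which in this assay gives 5.1 ug/mL, a gap within the scatter (a 1.7-fold higher number from compound 2 to compound 3 (0.24 log units; within the scatter)), whereas compound 1 `CCc1cccc2c(OC)c(-c3occ(C)c3C(=O)OC)ccc12` in this assay gives 1.3 ug/mL, so that a 6.8-fold higher number from compound 1 to compound 3 (0.83 log units; beyond the scatter). Compound 4 `CCc1cccc2c(OC)c(-c3occ(C)c3COC(=O)CCN(CC)CC)ccc12` carries (2-(diethylamino)ethyl)carbonyl in place of methyl on an oxygen on a saturated carbon. Among the measured compounds shown here, no measured step touches that oxygen; the steps of a 3.9-fold higher number from compound 1 to compound 2 (0.59 log units; beyond the scatter) and a 6.8-fold higher number from compound 1 to compound 3 (0.83 log units; beyond the scatter) concern only the group on the aromatic carbon, so they give weak guidance. The number for compound 4 is therefore expected to move little, meaning a 1.5-fold lower number from compound 3 to compound 4 (0.17 log units; within the scatter). The estimate for compound 4 in this assay is 6 ug/mL, within a range from 2 ug/mL to 18 ug/mL.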

Compound 4, concentration for half-maximal effect: > 10 ug/mL
Compound 4: a limit, no number; the forecaster's own chance of this, stated with the estimate: 5%; at least 1.6-fold (0.22 log units) between middle value and limit.
By their numbers in this assay, from the lowest: compound 1; then compounds 2 and 3 (each within the scatter of the next). At a limit, above all of these: compound 4.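

Compound 4 is the first compound shown with a change at the oxygen on a saturated carbon, where (2-(diethylamino)ethyl)carbonyl replaces methyl. In this assay compound 4 gives > 10 ug/mL, a limit and not a number: the limit of > 10 ug/mL in this assay, at which 1 of the 4 values shown sits. From the compounds shown here alone, the step, an at least 1.1-fold higher number from compound 3 to compound 4 (0.05 log units; that floor lies within the scatter), shows that this much larger group gave no lower number, while the true size of the change remains unknown.

Going by these compounds, whether a free hydroxyl or a small acetyl group on that oxygen would behave like methyl stays open. So does whether the diethylamino end or the carbonyl matters more.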